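The source may report more compounds than this note shows. Statements on the series, on what has been measured and on what is new or still open speak of the compounds shown alone.

Compound 1, `COc1nc2ccc(Br)cc2cc1C(c1ccccc1)n1cc(CCCO)nn1`: 13.8%.
Compound 2, `COc1nc2ccc(Br)cc2cc1C(c1ccccc1)n1cc(-c2ccc(OC(F)(F)F)cc2)nn1`: 14.8%.

In an ADME assay on SK-OV-3 cells (Homo sapiens) for cytotoxicity, read by sulforhodamine B assay, with a stated time of 48 h, tested at 10 uM (a higher number here means more inhibition at the concentration tested (going by the name of the read-out), a lower number less inhibition), compound 2 gives 14.8%, the higher of the two numbers, although the step of a number 1 percentage points higher from compound 1 to compound 2 (within the scatter) stays within the scatter. Compound 3, `COc1nc2ccc(Br)cc2cc1C(c1ccccc1)n1cc(CO)nn1`, differs from compound 2 by hydroxymethyl in place of 4-(trifluoromethoxy)phenyl on an aromatic carbon. For the measured compounds named here, the only measured step that bears on this, a number 1 percentage points higher from compound 1 to compound 2 (within the scatter), put 4-(trifluoromethoxy)phenyl in place of 3-hydroxypropyl and moved nothing beyond the scatter, so replacing that same aryl group with a short hydroxyl-bearing group is expected to give no step beyond the scatter either, a number 0.8 percentage points lower from compound 2 to compound 3 (within the scatter). Compound 3 is therefore estimated at 14%, ranging from 4% to 26%.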

Compound 3, a percentage reported as inhibition, at one concentration (the size of the read-out at that concentration, not a potency): 3.23%
Compound 3: the middle estimate sits 10.8 percentage points above what was measured; the whole stated range lies above it.
By their numbers in this assay, from the lowest: compound 3; then compounds 1 and 2 (each within the scatter of the next).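

In this assay, the group on this aromatic carbon does matter, which the earlier pair could not show: replacing 4-(trifluoromethoxy)phenyl with hydroxymethyl gives a number 11.6 percentage points lower from compound 2 to compound 3 (beyond the scatter), and shortening the 3-hydroxypropyl chain to hydroxymethyl gives a number 10.6 percentage points lower from compound 1 to compound 3 (beyond the scatter). Keeping a hydroxyl is therefore not enough to keep the number, since chain length alone separates these two hydroxyl-bearing compounds. Nothing available explains this drop.

Still open, as far as these compounds go, is whether a 2-hydroxyethyl chain would read like the longer or the shorter chain. From the compounds shown here alone, how an amine or a carboxylic acid at this position would read also remains unknown.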